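The source may report more compounds than this note shows. Statements on the series, on what has been measured and on what is new or still open speak of the compounds shown alone.

In a functional assay on PC-3 cells (Homo sapiens) for antiproliferative activity, read by MTT assay, with a stated time of 72 h (a lower number here means a stronger inhibitor, a higher number a weaker inhibitor), the measured compounds stand as follows:

compound 1 `O=C(N/N=C/c1ccc(Br)cc1)Nc1ccc(Oc2ccnc3[nH]ccc23)c(F)c1` gives 920 nM
compound 2 `O=C(N/N=C/c1ccc([N+](=O)[O-])cc1)Nc1ccc(Oc2ccnc3[nH]ccc23)c(F)c1` gives 150 nM
compound 3 `O=C(N/N=C/c1ccc(Br)cc1)Nc1ccc(Oc2ccnc3[nH]ccc23)cc1` gives "not active" (no number reported)

For the measured compounds named here, compound 3 has no single number, so it offers no fixed point to step from. Compound 4 `O=C(N/N=C/c1ccc([N+](=O)[O-])cc1)Nc1ccc(Oc2ccnc3[nH]ccc23)cc1` differs from compound 3 by nitro in place of bromo on an aromatic carbon and this is nitro in place of bromo on an aromatic carbon. Going by the values given here, the one measured step with this change is a 6.1-fold lower number from compound 1 to compound 2 (0.79 log units; beyond the scatter) and it is modest yet beyond the scatter. A step of about that size toward a lower number is therefore expected in this assay from an unknown starting point, and a result without a number remains possible. Compound 4 is expected near 900 nM with an estimated range from 150 nM to 5000 nM for now.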

Compound 4, half-maximal inhibitory concentration: 28100 nM
The estimate for compound 4 lay 31-fold (1.49 log units) below the measured number; the measured number lies above the stated range.
By their numbers in this assay, from the lowest: compound 2; then compound 1; then compound 4.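

In this assay, for the compounds shown here, hydrogen in place of fluoro on an aromatic carbon gives a 190-fold higher number from compound 2 to compound 4 (2.27 log units; beyond the scatter) and is the first reading of what the fluoro contributes with the 4-nitrophenyl held constant. Compound 3 also lacks the fluoro and has no number, so the steps to and from it cannot be read. No measurement at hand bears on the reason for this loss.

From the compounds shown here alone, whether a chloro or a methyl in place of the fluoro would keep the number of compound 2 stays open. So does the outcome of an amine in place of the nitro.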